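The source may report more compounds than this note shows. Statements on the series, on what has been measured and on what is new or still open speak of the compounds shown alone.

In an ADME assay on a cell-free system (plasma, Homo sapiens) for protein binding (a higher number here means a larger unbound share of the compound, a lower number a smaller unbound share), compound 1 `CC(C)COc1ncc(-c2cn(C)c3cc(C(=O)NS(=O)(=O)C4CC4)c(F)cc23)cc1Cl` gives < 0.001, which is a limit of the assay and not a number. Compound 1 stands at the limit of < 0.001 in this assay, at which 1 of the 3 values shown sits. Compound 3 `CC(C)COc1ncc(-c2cn(C)c3cc(C(=O)NS(C)(=O)=O)c(F)cc23)cc1Cl` gives 0.001. Compound 2 `Cn1nc(-c2ccc(C(F)(F)F)cc2)c2cc(F)c(C(=O)NS(=O)(=O)C3CC3)cc21` is recorded as "not determined" (no result reported), so it offers no guide.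

Compound 4 `CC(C)COc1ccc(-c2cn(C)c3cc(C(=O)NS(=O)(=O)C4CC4)c(F)cc23)cn1` differs from compound 1 in one place: hydrogen in place of chloro on an aromatic carbon. Within the data shown here, no measured step touches that place. Among the measured compounds shown here, the only measured step, a number no lower from compound 1 to compound 3 (the limit leaves the size open), puts methyl in place of cyclopropyl on a sulfonyl sulfur, and its size stays open. It bears on the new change only indirectly, by showing how little room the numbers have moved in. Compound 3, at 0.001, still keeps a very small unbound share after that swap, so a large jump seems unlikely here too. The expected size of an at least 1.5-fold higher number from compound 1 to compound 4 (0.17 log units; that floor lies within the scatter) is small, upward if anything, and perhaps no larger than the scatter. The assay may again report only a limit. For compound 4 the expected value is 0.0015, with an estimated range from 0.0006 to 0.004.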

Compound 4, unbound fraction: 0.024
Compound 4: the middle estimate sits 16-fold (1.20 log units) below what was measured; the measured number lies above the stated range.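

In this assay, among these compounds, this aromatic carbon proves to be a far more sensitive place than the earlier compounds could show: hydrogen in place of chloro gives an at least 24-fold higher number from compound 1 to compound 4 (1.38 log units; beyond the scatter). Among the compounds shown here, a single chlorine atom, ortho to an isobutoxy group and two atoms from the ring nitrogen, thus separates a compound at the floor of the assay from one with a readable unbound share, which the one earlier step, of unreadable size, could not reveal. The true size of this step stays open because compound 1 gives a limit and not a number: the limit of < 0.001 in this assay, at which 1 of the 4 values shown sits.

Going by these compounds, only hydrogen stands in for chloro here, so how fluoro, methyl or a nitrile at this carbon would read in this assay remains open. Also open, on these data alone, is whether the same swap would raise the number when methyl sits on the sulfonyl sulfur, as in compound 3.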